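The source may hold more compounds than are shown below. What is called first, only, known or untested is meant among the compounds shown, and "the series" means these compounds.

Three compounds built on a shared core have been examined in a toxicity assay on HepG2 cells (Homo sapiens) for cytotoxicity, read by MTT assay, with a stated time of 72 h; a lower number here means that less compound is tolerated, a higher number that more compound is tolerated. Compound 1 `O=C(Nc1ccc2nc(Nc3ccc(Cl)c(Cl)c3)c(Nc3ccc(Cl)c(Cl)c3)nc2c1)c1ccco1` carries a ((furan-2-yl)carbonyl)amino group on that core, and in this assay compound 1 gives 5690 nM. Compound 2 `O=[N+]([O-])c1ccc2nc(Nc3cccc(Cl)c3)c(Nc3cccc(Cl)c3)nc2c1` gives 580 nM in this assay. For compound 3 `O=[N+]([O-])c1ccc2nc(Nc3ccccc3)c(Nc3ccccc3)nc2c1` the outcome in this assay is "nd" (no result reported), so no number is available for it. Of the two numbers reported, compound 1 has the higher one, and the gap to compound 2 lies beyond the usual scatter, so compound 1 is the better tolerated of the two measured compounds. Among the compounds with values here, no pair of measured compounds differs in only one place, so no single step can be read from the measured set.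

Compound 4 `CC(=O)Nc1ccc2nc(Nc3ccc(Cl)c(Cl)c3)c(Nc3ccc(Cl)c(Cl)c3)nc2c1` has not yet been measured. It differs from compound 1 in one place: methyl in place of furan-2-yl on a carbonyl carbon. The acetamido group of compound 4 thus stands where the ((furan-2-yl)carbonyl)amino group of compound 1 stood, with the rest of the molecule unchanged. Nothing in the measured set shows what this exchange does in this assay. Within the data shown here, with no such step to lean on, the step of a 1.1-fold higher number from compound 1 to compound 4 (0.02 log units; within the scatter) is expected to be small and without a clear direction. Compound 4 is therefore estimated at 6000 nM in this assay, within a range of 2000 nM to 18000 nM.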

Compound 4, half-maximal cytotoxic concentration: 4590 nM
Compound 4: the middle estimate sits 1.3-fold (0.12 log units) above what was measured; the range from low to high includes it.
By their numbers in this assay, from the lowest: compound 2; then compounds 4 and 1 (each within the scatter of the next).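

In this assay, the set now holds its first step at a single place: methyl in place of furan-2-yl on a carbonyl carbon gives a 1.2-fold lower number from compound 1 to compound 4 (0.09 log units; within the scatter). This shows that, with the rest of the molecule unchanged, the five-membered aromatic ring can give way to a single carbon without a shift in this read-out that stands beyond the scatter, so this pair gives no sign that the furan-2-yl group matters to the tolerated concentration. No accompanying measurement bears on this result.

On these data alone, the step covers only these two groups on the carbonyl carbon, so it remains open whether a longer chain such as n-butyl, a phenyl ring or a group carrying a carboxylic acid there would also leave the number within the scatter, or whether a free amine in place of the whole acetamido group would do so. As far as these compounds go, it also remains open whether the same exchange would behave alike on a core bearing other anilino groups, since this single pair shares the same dichlorinated rings.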